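The source may hold more compounds than are shown below. What is called first, only, known or untested is meant among the compounds shown, and "the series" means these compounds.

Working notes on the series. Among the compounds with values here, in a functional assay on HEK293 cells for positive allosteric modulation of metabotropic glutamate receptor 5 (Homo sapiens), read by FLIPR and calcium flux (on this read-out higher numbers stand for an effect only at larger amounts of compound and lower numbers for an effect already at smaller amounts), three compounds have numbers so far. Compound 1, `O=C(COCc1ccncc1)N1CCN(c2ccc(Cl)cc2)CC1`, gives 1300 nM in this assay. Compound 2, `O=C(COCc1cnccn1)N1CCN(c2ccc(Cl)cc2Cl)CC1`, gives 5200 nM in this assay. Compound 3, `O=C(COCc1ccncc1)N1CCC(c2ccc(F)cc2Cl)CC1`, gives 370 nM in this assay. Compound 2 therefore stands at the highest number of the three, with compound 1 nearer to it and compound 3 furthest away, both gaps beyond the scatter.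

Compound 4, `O=C(CSc1ccccc1)N1CCN(c2ccc(Cl)cc2Cl)CC1`, has not yet been measured. It differs from compound 2 in one place: phenylsulfanyl in place of (pyrazin-2-yl)methoxy on a saturated chain carbon bound to a carbonyl carbon. Within the data shown here, no pair of measured compounds differing in exactly this way is available, so the size of the step from compound 2 is not anchored by data. Nothing in the three measured compounds points clearly in either direction; a step of modest size or none beyond the scatter is expected, with a mildly higher number somewhat more likely, and the step from compound 2 is expected to be about a 1.2-fold higher number from compound 2 to compound 4 (0.06 log units; within the scatter). In this assay compound 4 is estimated at 6000 nM, within a range from 1500 nM to 20000 nM.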

Compound 4, half-maximal effective concentration: > 25000 nM
Compound 4: only a limit was reported (the forecaster's own chance of this, stated with the estimate: 25%); middle value at least 4.1-fold (0.61 log units) away from the limit.
By their numbers in this assay, from the lowest: compound 3; then compound 1; then compound 2. At a limit, above all of these: compound 4.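

Within the data shown here, this is the first step that isolates one change, on a saturated chain carbon bound to a carbonyl carbon: in this assay, phenylsulfanyl in place of (pyrazin-2-yl)methoxy gives an at least 4.8-fold higher number from compound 2 to compound 4 (0.68 log units; beyond the scatter). The earlier compounds shown here differ from one another in more than one place, so they could not show that this position alone can move the number beyond the scatter. Compound 4 stands at a limit of the assay: the limit of > 25000 nM in this assay, at which 1 of the 4 values shown sits.

The compounds shown leave open whether the step follows the loss of the ring nitrogens, the sulfur link or the shorter link to the ring, and how the same change behaves on other cores. From the compounds shown here alone, it also remains open whether phenoxy or benzyloxy at this place would stand with compound 2 or with compound 4.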